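A few compounds are considered here, and "the series" means these few. Any claim that something is new, unique, unknown or untested is made for them only; others in the source may bear on it.

Measured in an ADME assay on Vero cells (Chlorocebus sabaeus) for cytotoxicity, read by resazurin assay, with a stated time of 72 h; on this read-out higher numbers stand for weaker inhibition and lower numbers for stronger inhibition:
compound 1 `Cc1ccc(C(=O)CCN2CCN(c3ccc(C(F)(F)F)cc3)CC2)cc1` gives 140000 nM
compound 2 `COc1ccc(C(=O)CCN2CCN(c3ccc(C(F)(F)F)cc3)CC2)cc1OC` gives 243000 nM
compound 3 `COc1ccc(C(=O)CCN2CCN(c3ccc([N+](=O)[O-])cc3)CC2)cc1OC` gives 105000 nM

Compound 2 stands at 243000 nM, and the two measured steps around it are a 1.7-fold higher number from compound 1 to compound 2 (0.24 log units; within the scatter) and a 2.3-fold lower number from compound 2 to compound 3 (0.36 log units; beyond the scatter). Compound 4 `O=C(CCN1CCN(c2ccc(C(F)(F)F)cc2)CC1)c1ccc(F)c(F)c1` has not yet been measured. It carries 3,4-difluorophenyl in place of 3,4-dimethoxyphenyl on a carbonyl carbon. Among the measured compounds shown here, only one measured step changes the group on that carbonyl carbon, namely a 1.7-fold higher number from compound 1 to compound 2 (0.24 log units; within the scatter), and it stayed small. The other step, a 2.3-fold lower number from compound 2 to compound 3 (0.36 log units; beyond the scatter), changes a different group, so it shows only how far these numbers have moved at all. For the measured compounds named here, no measured compound carries the 3,4-difluorophenyl group. In this assay a step no larger than the scatter is therefore expected, with no firm direction. The estimated step is a 1.4-fold lower number from compound 2 to compound 4 (0.16 log units; within the scatter). Compound 4 is expected at 170000 nM, with an estimated range from 85000 nM to 330000 nM.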

Compound 4, half-maximal inhibitory concentration: 14000 nM
Beside the measured number, compound 4's estimate is 12-fold (1.08 log units) above it, outside the stated range (below it).
By their numbers in this assay, from the lowest: compound 4; then compounds 3, 1 and 2 (each within the scatter of the next, the first and the last beyond it).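

In this assay, the group on the carbonyl carbon proved able to move the number far beyond the scatter: 3,4-difluorophenyl in place of 3,4-dimethoxyphenyl gave a 17-fold lower number from compound 2 to compound 4 (1.24 log units; beyond the scatter), and in place of 4-methylphenyl it gave a 10-fold lower number from compound 1 to compound 4 (1.00 log units; beyond the scatter). The one earlier step at this position, a 1.7-fold higher number from compound 1 to compound 2 (0.24 log units; within the scatter), had shown no such sensitivity, so the position is less indifferent to its group than that pair suggested. Nothing available here explains the shift.

The compounds shown leave open whether one fluorine, as in 4-fluorophenyl, or another halogen, as in 3,4-dichlorophenyl, would move the number as far. Also open, on these data alone, is whether 3,4-difluorophenyl would act the same way with nitro in place of trifluoromethyl.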